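Chlorophenyl piperazines on a propyl oxazole core

The source may hold more compounds than are shown below. What is called first, only, known or untested is meant among the compounds shown, and "the series" means these compounds.

Two compounds of this series have been run in an assay on HEK293 cells for inhibition of Voltage-dependent T-type calcium channel subunit alpha-1G (Homo sapiens), read by fluorescence, tested at 10 uM; on this read-out higher numbers stand for more inhibition at the one concentration tested (going by the name of the read-out) and lower numbers for less inhibition. Compound 1 `CCCc1nc(-c2ccccc2)c(CNCCN2CCN(c3ccccc3Cl)CC2)o1` gives 60.1% in this assay and stands highest of the two numbers. Compound 2 `CCCc1nc(-c2ccccc2)c(CNCCCN2CCN(c3cccc(C)c3)CC2)o1` gives 47.8% in this assay, a number beyond the scatter below compound 1; the two structures differ in more than one place, so nothing is set down as a single step between them.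

Compound 3 `CCCc1nc(-c2ccccc2)c(CNCCN2CCN(c3cccc(Cl)c3)CC2)o1` has not yet been measured. It is compound 1 with 3-chlorophenyl in place of 2-chlorophenyl on an amine nitrogen in a ring. Going by the values given here, no step between two measured compounds in this assay isolates this change, so the expectation rests on compound 1 alone. The step of a number 5.1 percentage points lower from compound 1 to compound 3 (within the scatter) is expected to be small, most likely within the scatter, with a slight lean downward. Compound 3 is therefore estimated at 55% in this assay, with a range from 35% to 75%.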

Compound 3, a percentage reported as inhibition, at one concentration (the size of the read-out at that concentration, not a potency): 51.2%
The estimate for compound 3 lay 3.8 percentage points above the measured number, and the stated range covers the measured number.
By their numbers in this assay, from the lowest: compounds 2, 3 and 1 (each within the scatter of the next, the first and the last beyond it).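

In this assay, going by these compounds alone, 3-chlorophenyl in place of 2-chlorophenyl on an amine nitrogen in a ring gives a number 8.9 percentage points lower from compound 1 to compound 3 (within the scatter), the first step that isolates a single place. At this one concentration the two chlorophenyl groups therefore cannot be told apart on this ring nitrogen, so the change of chlorine position gives no usable separation between compound 1 and compound 3. No measured information bears on why the step has this size.

From the compounds shown here alone, whether 4-chlorophenyl, 2-methoxyphenyl or unsubstituted phenyl on the same nitrogen would stay within the scatter of compound 1 remains open. The chain length cannot be read on its own either, as compound 2 differs from both compound 1 and compound 3 in more than one place.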